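From isopropyl to pyridin-4-yl on a carbonyl carbon

The compounds below may be only part of what the source reports. "The series", "measured", "known", "first", "only" and "open" are said of these compounds alone.

Measured so far in a physicochemical assay for lipophilicity, read by HPLC, measured as chromatographic lipophilicity, at pH 7.4; on this read-out higher numbers stand for higher lipophilicity and lower numbers for lower lipophilicity 
Compound 1 `Cc1ccc(C2CC=NN2C(=O)C(C)(C)C)cc1` gives 6.4 
Compound 2 `CC(C)C(=O)N1N=CCC1c1ccccc1` gives 4.4 

Compound 2 at 4.4 stands lowest of the two, and compound 1 at 6.4 lies higher, beyond the usual scatter. Among the measured compounds shown here, these two compounds differ in more than one place, so the data hold no single-change step to lean on. Compound 3 `O=C(c1ccncc1)N1N=CCC1c1ccccc1` has not yet been measured. For the measured compounds named here, it keeps the rest of compound 2 and carries pyridin-4-yl in place of isopropyl on a carbonyl carbon as its only change. The step expected in this assay is a fall beyond the scatter, estimated as a number 0.80 log units lower from compound 2 to compound 3 (beyond the scatter) on this read-out. That expectation starts from compound 2 at 4.4 and rests on the structural change alone. For compound 3 the expected value is 3.6 with 2.9 to 4.3 as its range.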

Compound 3, distribution coefficient: 2.7
The estimate for compound 3 lay 0.90 log units above the measured number; measured number outside the range, below it.
By their numbers in this assay, from the lowest: compound 3; then compound 2; then compound 1.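

In this assay the data now hold a single-place step, and it is large: a number 1.70 log units lower from compound 2 to compound 3 (beyond the scatter) when pyridin-4-yl takes the place of isopropyl on a carbonyl carbon whose other neighbour is an amide-type nitrogen in a ring. This shows that the number responds strongly to the group at this position, and that it can fall beyond the scatter even when the entering group has more heavy atoms than the one leaving. No measurement at hand speaks to why this step is so large.

On these data alone, it remains open whether a plain phenyl group on the same carbonyl carbon would give a step of similar size, which would separate the effect of the ring from that of its nitrogen. Also open, as far as these compounds go, is how a longer alkyl chain or a morpholine at this position would compare with isopropyl and pyridin-4-yl.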